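Cytotoxicity in HEL cells: allyl ether replacing 3-chlorobenzyl ether

The source may report more compounds than this note shows. Statements on the series, on what has been measured and on what is new or still open speak of the compounds shown alone.

Measured so far in an ADME assay on HEL cells (Homo sapiens) for cytotoxicity, with a stated time of 3 days; a lower number here means that less compound is tolerated, a higher number that more compound is tolerated:
compound 1 `CCC1(Cc2ccccc2)OS(=O)(=O)C=C1OCc1ccc(C)cc1` gives 41500 nM.
compound 2 `CCC1(Cc2ccccc2)OS(=O)(=O)C=C1OC(=O)c1ccccc1` gives only the assay limit > 200000 nM.
compound 3 `CCC1(Cc2ccccc2)OS(=O)(=O)C=C1OCc1cccc(Cl)c1` gives 50000 nM.

Compound 3 and compound 1 sit within the scatter of each other, a 1.2-fold higher number from compound 1 to compound 3 (0.08 log units; within the scatter). The two steps that move to benzoyl, an at least 4.8-fold higher number from compound 1 to compound 2 (0.68 log units; beyond the scatter) and an at least 4.0-fold lower number from compound 2 to compound 3 (0.60 log units; beyond the scatter), reach only the limit of > 200000 nM in this assay, at which 1 of the 3 values shown sits, and concern a different part of the structure.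

Compound 4 `C=CCOC1=CS(=O)(=O)OC1(CC)Cc1ccccc1` differs from compound 3 in vinyl in place of 3-chlorophenyl on a saturated chain carbon bound to an oxygen on an unsaturated carbon. Among the compounds with values here, the only measured step at this place, a 1.2-fold higher number from compound 1 to compound 3 (0.08 log units; within the scatter), stayed within the scatter, but it kept the aromatic ring, which now leaves entirely; no measured step covers that. In this assay no step beyond the scatter is therefore expected, with the uncertainty wider than usual.

Compound 4 is expected to give 60000 nM (range 25000 nM to 150000 nM), an estimated step of a 1.2-fold higher number from compound 3 to compound 4 (0.08 log units; within the scatter).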

Compound 4, half-maximal cytotoxic concentration: > 200000 nM
Compound 4: no number, only a limit; the forecaster's own chance of this, stated with the estimate: 15%; middle value at least 3.3-fold (0.52 log units) from the limit.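

In this assay, the aromatic ring at this place turns out to matter: an at least 4.0-fold higher number from compound 3 to compound 4 (0.60 log units; beyond the scatter), and an at least 4.8-fold higher number from compound 1 to compound 4 (0.68 log units; beyond the scatter), whereas swapping one substituted aromatic ring for the other stayed within the scatter, a 1.2-fold higher number from compound 1 to compound 3 (0.08 log units; within the scatter). The value of compound 4 is a limit, not a number, and the step between compound 2 and compound 4 cannot be read: the limit of > 200000 nM in this assay, at which 2 of the 4 values shown sit.

Still open, from the compounds shown here alone, is how far the allyl ether's value lies from those of the benzyl ethers. A propyl or unsubstituted benzyl ether would help separate the loss of the aromatic ring from the entry of the double bond.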